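Bromo to Iodo on the Shared Core

The compounds below may be only part of what the source reports. "The series", "measured", "known", "first", "only" and "open" are said of these compounds alone.

Of the compounds shown here, three on one shared core have been measured in an ADME assay on the whole organism with Oryza sativa as the target, tested at 0.1 uM; on this read-out lower numbers stand for a stronger effect and higher numbers for a weaker effect at the one concentration tested. Compound 1 `C[C@H](NC(=O)Nc1ccccc1C(F)(F)F)c1ccccc1` gives 97% there. Compound 2 `C[C@H](NC(=O)Nc1ccccc1F)c1ccccc1` gives 98% in this assay, and compound 3 `C[C@H](NC(=O)Nc1ccccc1Br)c1ccccc1` gives 101%. Compound 3 holds the highest of the three numbers, yet its step from compound 2 is a number 3 percentage points higher from compound 2 to compound 3 (within the scatter) and the step from compound 1 is a number 4 percentage points higher from compound 1 to compound 3 (within the scatter), so all three sit together inside the scatter.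

The next compound, compound 4 `C[C@H](NC(=O)Nc1ccccc1I)c1ccccc1`, differs from compound 3 in one place: iodo in place of bromo on an aromatic carbon. Going by the values given here, the steps that bear on this change are the earlier replacements on that aromatic carbon, a number 1 percentage points higher from compound 1 to compound 2 (within the scatter), a number 4 percentage points higher from compound 1 to compound 3 (within the scatter) and a number 3 percentage points higher from compound 2 to compound 3 (within the scatter), none of which reached beyond the scatter. A move from bromo to iodo on the aromatic carbon is therefore expected to give no step beyond the scatter in this assay, the expected step being a number 1 percentage points lower from compound 3 to compound 4 (within the scatter). Compound 4 is accordingly estimated at 100% in this assay, with a range running from 91% to 109%.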

Compound 4, a percentage reported as activity, at one concentration (the size of the read-out at that concentration, not a potency): 99%
For compound 4 the middle estimate is 1 percentage points above the measured one, within the range that was stated.
By their numbers in this assay, from the lowest: compounds 1, 2, 4 and 3 (each within the scatter of the next).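

With iodo on the aromatic carbon, ortho to a large group, the shared core now carries a fourth group at this position, and in this assay the new steps of a number 2 percentage points lower from compound 3 to compound 4 (within the scatter) and a number 1 percentage points higher from compound 2 to compound 4 (within the scatter) and a number 2 percentage points higher from compound 1 to compound 4 (within the scatter) all stay within the scatter. Iodo therefore joins trifluoromethyl, fluoro and bromo as a group that this read-out does not separate from the others at this position, a finding that holds for these four compounds and for the one concentration tested. No supporting measurement bears on this result, so the flat picture stands without an explanation.

The compounds shown leave open whether any group of a different kind on this aromatic carbon, such as an amine, a carboxylic acid or a longer chain, would give a step beyond the scatter in this assay at all. They also leave open whether these four halogen-bearing and trifluoromethyl groups would stay together at another concentration, or if they were placed elsewhere on the shared core.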